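Aryl replacements for chloro on the shared core

The compounds below may be only part of what the source reports. "The series", "measured", "known", "first", "only" and "open" are said of these compounds alone.

Compound 1 `COc1cc(-c2ccnc3cc(-c4ccc(Cl)cc4)nn23)cc(OC)c1OC` carries a 4-chlorophenyl on the shared core. In a functional assay on MCF7 cells (Homo sapiens) for inhibition, read by CCK-8 assay, with a stated time of 48 h (on this read-out higher numbers stand for weaker inhibition and lower numbers for stronger inhibition), compound 1 gives 2320 nM, the highest number among the three measured compounds. Compound 2 `COc1cc(-c2ccnc3cc(-c4ccc5c(ccn5C)c4)nn23)cc(OC)c1OC` gives 3 nM, and compound 3 `COc1ccc(-c2cc3nccc(-c4cc(OC)c(OC)c(OC)c4)n3n2)cc1N` gives 27 nM. Both measured steps from compound 1 exchange the whole 4-chlorophenyl for another aromatic group: a 770-fold lower number from compound 1 to compound 2 (2.89 log units; beyond the scatter) and an 86-fold lower number from compound 1 to compound 3 (1.93 log units; beyond the scatter). Between those two replacements, a 9.0-fold higher number from compound 2 to compound 3 (0.95 log units; beyond the scatter).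

Compound 4 `COc1cc(-c2ccnc3cc(-c4ccc(-c5cnn(C)c5)cc4)nn23)cc(OC)c1OC` is not yet measured. It differs from compound 1 as follows: 1-methyl-1H-pyrazol-4-yl in place of chloro on an aromatic carbon. Here the phenyl itself stays, and only the chloro gives way to a further aromatic ring, so the change is of the same kind as the two measured steps only in that the group on the shared core grows from a halogenated phenyl to a ring-bearing aromatic group. For the measured compounds named here, both measured steps were large and lowered the number, and no measured compound shows a move of this kind that failed to do so. A large lowering in this assay is therefore expected, with a wide range since neither measured compound keeps the phenyl with an added ring. Compound 4 is expected at 30 nM, between 5 nM and 250 nM, which would mean a 77-fold lower number from compound 1 to compound 4 (1.89 log units; beyond the scatter).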

Compound 4, half-maximal inhibitory concentration: 274 nM
Compound 4: middle estimate off by 9.1-fold (0.96 log units), on the low side, outside the stated range (above it).
By their numbers in this assay, from the lowest: compound 2; then compound 3; then compound 4; then compound 1.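

Keeping the phenyl and changing only the group para to a large group still lowers the number in this assay, with an 8.5-fold lower number from compound 1 to compound 4 (0.93 log units; beyond the scatter), so the 4-chlorophenyl can be improved without replacing the whole aromatic group. The step is only modest, however, and compound 4 at 274 nM remains higher in number than compound 3 at 27 nM and compound 2 at 3 nM, so adding a 1-methyl-1H-pyrazol-4-yl to the phenyl does not reach the values of the two whole-group replacements. No available evidence bears on why this exchange gives a smaller step than those replacements.

The compounds shown do not separate the loss of the chloro from the arrival of the new ring, and a plain phenyl with hydrogen at that place would be the direct test. As far as these compounds go, it also remains open how a morpholine, a carboxylic acid or a pyrazole without its methyl group would compare at the same place on the phenyl, so the present step cannot yet be read as a trend for this position.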